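The compounds below may be only part of what the source reports. "The series", "measured", "known", "first", "only" and "open" are said of these compounds alone.

Measured in a physicochemical assay for solubility, read by HPLC, using the shake flask method, in phosphate buffer, with a stated time of 20 h, at pH 6.5; on this read-out lower numbers stand for lower solubility and higher numbers for higher solubility:
Compound 1 `CN1CCN(C2CCN(c3nccc4[nH]c(-c5ccc(F)c(F)c5)nc34)CC2)CC1` gives 130000 nM
Compound 2 `CN(C)C1CCN(c2nccc3[nH]c(-c4cccc(OC(F)(F)F)c4)nc23)CC1` gives 180000 nM
Compound 3 `CN1CCN(C2CCN(c3nccc4[nH]c(-c5cccc(OC(F)(F)F)c5)nc34)CC2)CC1` gives 190000 nM

Compound 3, at 190000 nM, stands within the scatter of both other compounds, so these three numbers show no order. Compound 4 `CN1CCN(C2CCN(c3nccc4[nH]c(-c5cccc(S(C)(=O)=O)c5)nc34)CC2)CC1`, not yet measured, carries methylsulfonyl in place of trifluoromethoxy on an aromatic carbon and otherwise matches compound 3. Among the measured compounds shown here, two measured steps bear on this change. Exchanging the group on the aromatic carbon gave a 1.5-fold higher number from compound 1 to compound 3 (0.16 log units; within the scatter) and is the nearer guide. Exchanging the group on the saturated ring gave a 1.1-fold higher number from compound 2 to compound 3 (0.02 log units; within the scatter) and shows how little the numbers have moved so far. For the measured compounds named here, no measured compound carries methylsulfonyl, so the data offer no direct precedent. No step beyond the scatter is therefore expected in this assay, and no direction can be favoured. The estimated change is a 1.1-fold higher number from compound 3 to compound 4 (0.02 log units; within the scatter). For compound 4 the estimated value is 200000 nM, with an expected range of 100000 nM to 400000 nM.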

Compound 4, solubility: 190000 nM
Estimate against measurement, compound 4: 1.1-fold (0.02 log units) above; the range from low to high includes it.
By their numbers in this assay, from the lowest: compounds 1, 2, 3 and 4 (each within the scatter of the next).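

In this assay the aromatic carbon meta to a large group accepts methylsulfonyl in place of trifluoromethoxy with no change at the digits printed from compound 3 to compound 4 (within the scatter) and so a sulfur-bearing group with two double bonds outside aromatic rings joins the fluorinated groups at this place. Measured against the 3,4-difluorophenyl compound, 3-(methylsulfonyl)phenyl gives a 1.5-fold higher number from compound 1 to compound 4 (0.16 log units; within the scatter) and so compounds 1, 3 and 4 all lie within the scatter of one another, with no group at this place setting any of them apart. Nothing measured here accounts for this flatness.

On these data alone, whether an amine or a carboxylic acid on this aromatic carbon would leave the number within the scatter stays open. So does whether methylsulfonyl would match trifluoromethoxy with dimethylamino on the saturated ring carbon.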